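Chloro to Fluoro: Expecting a Fourth Compound

The source may hold more compounds than are shown below. What is called first, only, known or untested is meant among the compounds shown, and "the series" means these compounds.

Compound 1, compound 2 and compound 3 have so far been tested in an assay on cells for inhibition of Amine oxidase [flavin-containing] A (Homo sapiens), read by fluorescence and spectrophotometry, using microsomes, with a stated time of 20 min; a higher number here means a weaker inhibitor, a lower number a stronger inhibitor. Compound 1 `NS(=O)(=O)c1cccc(-c2nnc(-c3ccc(F)cc3)o2)c1` gives 34400 nM. Compound 2 `NS(=O)(=O)c1cccc(-c2nnc(-c3ccc(Cl)cc3)o2)c1` reaches only a limit of the assay, > 100000 nM, so no number is known for it. Compound 3 `NS(=O)(=O)c1ccc(-c2nnc(-c3ccc(Cl)cc3)o2)cc1` gives 68000 nM. The values of compound 1 and compound 3 lie within the usual scatter of each other, so the two cannot be told apart.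

Compound 2 and compound 1 differ in a single place: fluoro in place of chloro on an aromatic carbon. This change produced an at least 2.9-fold lower number from compound 2 to compound 1 (0.46 log units; beyond the scatter). The step rests on (the limit of > 100000 nM in this assay, at which 1 of the 3 values shown sits), so its full size is not fixed. Compound 2 and compound 3 are built from the same atoms joined differently; the difference between the two cores is not broken down here.

Compound 4 `NS(=O)(=O)c1ccc(-c2nnc(-c3ccc(F)cc3)o2)cc1` has not yet been measured. Within the data shown here, it differs from compound 3 by fluoro in place of chloro on an aromatic carbon, which is the same change as the one from compound 2 to compound 1, at the same kind of position on the same kind of ring.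

In this assay compound 4 is therefore expected to give 30000 nM, with a likely range from 12000 nM to 80000 nM. This estimate means an expected step of a 2.3-fold lower number from compound 3 to compound 4 (0.36 log units; beyond the scatter), modelled on the earlier at least 2.9-fold lower number from compound 2 to compound 1 (0.46 log units; beyond the scatter) but kept modest because that earlier step rests on (the limit of > 100000 nM in this assay, at which 1 of the 3 values shown sits).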

Compound 4, half-maximal inhibitory concentration: 83800 nM
Compound 4: the middle estimate sits 2.8-fold (0.45 log units) below what was measured, and the stated range ends below it.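

In this assay the change from 4-chlorophenyl to 4-fluorophenyl gives a 1.2-fold higher number from compound 3 to compound 4 (0.09 log units; within the scatter), so on this core the two compounds cannot be told apart. The same swap of one halogen for the other therefore did not carry over from one core to the other with the same size: the same change on two cores in this assay, an at least 2.9-fold lower number (0.46 log units; beyond the scatter) from compound 2 to compound 1 and a 1.2-fold higher number (0.09 log units; within the scatter) from compound 3 to compound 4, at least 3.5-fold (0.55 log units) apart, beyond the scatter of two such steps. Nothing here says why the two cores respond differently, and compound 2 stands at a limit of the assay rather than at a number, which leaves the full size of the earlier step unfixed: the limit of > 100000 nM in this assay, at which 1 of the 4 values shown sits.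

The compounds shown carry only chloro or fluoro in this place, so it stays open whether a methoxy group, a nitrile or an amine there would shift the number on either core. All four also keep the same sulfonamide, and what a carboxylic acid in its stead would do, on either core, remains an open question as well.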